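The source may report more compounds than this note shows. Statements on the series, on what has been measured and on what is new or still open speak of the compounds shown alone.

Three compounds have been measured in a functional assay, read by spectrophotometry, with a stated time of 2 h, tested at 0.5 mg/mL; on this read-out higher numbers stand for a stronger effect at the one concentration tested and lower numbers for a weaker effect:
compound 1 `CC(C)[C@@H]1CC[C@@H](C)C[C@@]12N(C)C(=O)[C@@H]1[C@H]3C(=O)NC(=O)[C@H]3ON12`, 23.5%;
compound 2 `CC(C)[C@@H]1CC[C@@H](C)C[C@@]12N(C)C(=O)[C@@H]1[C@H]3C(=O)N(c4ccccc4)C(=O)[C@H]3ON12`, 14.7%;
compound 3 `Cc1cccc(N2C(=O)[C@H]3[C@H](ON4[C@@H]3C(=O)N(C)[C@@]43C[C@H](C)CC[C@H]3C(C)C)C2=O)c1`, 16.1%.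

Compound 1 stands highest of the three numbers, yet its steps to the others stay within the scatter: a number 8.8 percentage points lower from compound 1 to compound 2 (within the scatter) and a number 7.4 percentage points lower from compound 1 to compound 3 (within the scatter). Between the two aryl compounds, a number 1.4 percentage points higher from compound 2 to compound 3 (within the scatter).

Compound 4 `Cc1ccc(N2C(=O)[C@H]3[C@H](ON4[C@@H]3C(=O)N(C)[C@@]43C[C@H](C)CC[C@H]3C(C)C)C2=O)c(C)c1` differs from compound 1 in one place: 2,4-dimethylphenyl in place of hydrogen on an amide-type nitrogen in a ring. The two steps that bear on it, each an aryl group entering at the same nitrogen, were both small and within the scatter, so in this assay only a small downward step, or none beyond the scatter, is expected. Compound 4 is therefore estimated at 15.5%, within a range from 5% to 26%, which would mean an expected step of a number 8 percentage points lower from compound 1 to compound 4 (within the scatter).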

Compound 4, a percentage reported as activity, at one concentration (the size of the read-out at that concentration, not a potency): 52.9%
The estimate for compound 4 lay 37.4 percentage points below the measured number, and the stated range ends below it.
By their numbers in this assay, from the lowest: compounds 2, 3 and 1 (each within the scatter of the next); then compound 4.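

At the amide-type nitrogen in a ring, an aryl group is not one uniform change in this assay: 2,4-dimethylphenyl in place of hydrogen gives a number 29.4 percentage points higher from compound 1 to compound 4 (beyond the scatter), while the phenyl and 3-methylphenyl steps from hydrogen stayed within the scatter. The aryl-for-aryl steps are larger, with a number 36.8 percentage points higher from compound 3 to compound 4 (beyond the scatter) and a number 38.2 percentage points higher from compound 2 to compound 4 (beyond the scatter), so the groups on the aromatic ring decide the outcome here. No available evidence bears on this result. The compounds shown leave open whether both methyl groups of the 2,4-dimethylphenyl are needed, and whether chlorine or an amine in their place would keep the number.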